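Cyclopropylamine in place of ethylpiperazine on the diaryl ether core

A few compounds are considered here, and "the series" means these few. Any claim that something is new, unique, unknown or untested is made for them only; others in the source may bear on it.

Two measured compounds anchor the series. Compound 1 `CCN1CCN(Cc2c(OC)cc(Oc3cccc(Nc4ccccc4)c3)cc2OC)CC1` gives no number in a functional assay on HCT-116 cells (Homo sapiens) for inhibition, read by MTT assay, with a stated time of 72 h; on this read-out lower numbers stand for stronger inhibition and higher numbers for weaker inhibition; the read-out is a limit, > 20000 nM, and compound 1 sits at the limit of > 20000 nM in this assay, at which 1 of the 2 values shown sits. Going by the values given here, compound 2 `COc1ccc(CCCNCc2c(OC)cc(Oc3ccc(Nc4ccccc4)cc3)cc2OC)cc1` is the only member with a measured value, and in this assay compound 2 gives 3230 nM. Among the compounds with values here, no single-point step links compound 1 and compound 2, so the two values show only that one carries a limit and the other a number. Compound 3 `COc1cc(Oc2cccc(Nc3ccccc3)c2)cc(OC)c1CNC1CC1` has not yet been measured in this assay. It differs from compound 1 by cyclopropylamino in place of 4-ethylpiperazin-1-yl on a saturated chain carbon bound to an aromatic carbon. The change exchanges a group carrying no hydrogen-bond donor for one carrying one, on a saturated chain carbon bound to an aromatic carbon, a feature that compound 2 shares. Given that compound 1 rests at a limit, the expected step in this assay is toward a lower number, of modest size, with a fair chance that only a limit is reported again. The expected step runs an at least 2.2-fold lower number from compound 1 to compound 3 (0.34 log units; beyond the scatter). Compound 3 is estimated at 9000 nM in this assay, with a likely range from 2500 nM to 25000 nM.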

Compound 3, half-maximal inhibitory concentration: > 20000 nM
Compound 3 was reported as a limit; the forecaster's own chance of this, stated with the estimate: 35%; middle value at least 2.2-fold (0.34 log units) away from the limit.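

In this assay compound 3 gives > 20000 nM, which is a limit. Compound 1 also stands at a limit, so no step can be read between compound 1 and compound 3. The series now reads: the limit of > 20000 nM in this assay, at which 2 of the 3 values shown sit.

The compounds shown leave open whether cyclopropylamino in place of 4-ethylpiperazin-1-yl changes the read-out at all, and by how much.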